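This account rests on a few compounds, and the source may have more. Where it says the series, first, only, none or still open, it means among the compounds named here.

Compound 3 `CN1CCN(c2nc3ccccc3n2CCOCCO)CC1` gives 42 nM in a functional assay on ileum for inhibition of histamine H1 receptor (Cavia porcellus) (a higher number here means a weaker inhibitor, a lower number a stronger inhibitor), the second highest of the three numbers: compound 2 `CCSCCn1c(N2CCN(C)CC2)nc2ccccc21` gives 19 nM, while compound 1 `CCNCCn1c(N2CCN(C)CC2)nc2ccccc21` gives 290 nM. The step of a 2.2-fold higher number from compound 2 to compound 3 (0.34 log units; beyond the scatter) is modest; the steps of a 15-fold lower number from compound 1 to compound 2 (1.18 log units; beyond the scatter) and a 6.9-fold lower number from compound 1 to compound 3 (0.84 log units; beyond the scatter) are larger. Compound 4 `COCCCn1c(N2CCN(C)CC2)nc2ccccc21` carries methoxymethyl in place of 2-hydroxyethoxy on a saturated chain carbon, two bonds along the chain from an aromatic nitrogen. Among the measured compounds shown here, no measured step covers methoxymethyl at this place; what the series shows is that the ethylsulfanyl of compound 2 and the 2-hydroxyethoxy of compound 3 give the lower numbers and the ethylamino of compound 1 the highest. A shift no larger than a 2.2-fold higher number from compound 2 to compound 3 (0.34 log units; beyond the scatter) is therefore expected, toward a lower number or none beyond the scatter. Compound 4 is estimated at 30 nM in this assay, between 10 nM and 90 nM, a step of a 1.4-fold lower number from compound 3 to compound 4 (0.15 log units; within the scatter) being expected.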

Compound 4, half-maximal inhibitory concentration: 860 nM
Beside the measured number, compound 4's estimate is 29-fold (1.46 log units) below it; the whole stated range lies below it.
By their numbers in this assay, from the lowest: compound 2; then compound 3; then compound 1; then compound 4.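

In this assay, this position tolerates much less than the first three compounds suggested: a 20-fold higher number from compound 3 to compound 4 (1.31 log units; beyond the scatter) and a 45-fold higher number from compound 2 to compound 4 (1.66 log units; beyond the scatter) show that an ether oxygen in the chain does not by itself keep the number low. The 3-methoxypropyl chain also falls behind the ethylamino group, with a 3.0-fold higher number from compound 1 to compound 4 (0.47 log units; beyond the scatter), so compound 4 now has the highest number of the series. No available evidence explains this loss.

The step to compound 4 changes the chain and removes the terminal hydroxyl together, and the compounds shown do not separate these two changes. A 3-hydroxypropyl chain and a 2-(2-methoxyethoxy)ethyl chain would each test one change alone.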